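A few compounds are considered here, and "the series" means these few. Any claim that something is new, unique, unknown or untested is made for them only; others in the source may bear on it.

Compounds measured in a functional assay on HGC-27 cells (Homo sapiens) for inhibition, read by MTT assay, with a stated time of 72 h; a lower number here means a stronger inhibitor, a higher number a weaker inhibitor:
compound 1, `Cc1cc(N2CC[C@@H](C)[C@@H](N(C)c3ncnc4[nH]ccc34)C2)n2nc(SCc3cc(Cl)ccc3Cl)nc2n1`, 19200 nM;
compound 2, `Cc1cc(N2CC[C@@H](C)[C@@H](N(C)c3ncnc4[nH]ccc34)C2)n2nc(SCc3nc4ccccc4[nH]3)nc2n1`, > 100000 nM, which is a limit of the assay rather than a number;
compound 3, `Cc1cc(N2CC[C@@H](C)[C@@H](N(C)c3ncnc4[nH]ccc34)C2)n2nc(SCCc3ccccc3)nc2n1`, 11800 nM.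

Only two numbers are shown. Compound 3 and compound 1 lie within the scatter of each other, the step being a 1.6-fold lower number from compound 1 to compound 3 (0.21 log units; within the scatter). The value of compound 2 is a limit (the limit of > 100000 nM in this assay, at which 1 of the 3 values shown sits), so the steps of an at least 5.2-fold higher number from compound 1 to compound 2 (0.71 log units; beyond the scatter) and an at least 8.4-fold lower number from compound 2 to compound 3 (0.92 log units; beyond the scatter) can only be given as minimum sizes.

Compound 4, `Cc1cc(N2CC[C@@H](C)[C@@H](N(C)c3ncnc4[nH]ccc34)C2)n2nc(SCCCc3ccccc3)nc2n1`, has not yet been measured. It differs from compound 3 by benzyl in place of phenyl on a saturated chain carbon, two bonds along the chain from a sulfur. Among the measured compounds shown here, no measured step changes the length of the chain between the sulfur and the phenyl ring in this way; the step from compound 1 to compound 3 exchanges the group on the chain carbon bound to the sulfur and stays within the scatter. Nothing in the shown steps points to a change in either direction for compound 4, so the expected step is a 1.0-fold higher number from compound 3 to compound 4 (0.01 log units; within the scatter), with no movement beyond the scatter. Compound 4 is therefore estimated at 12000 nM, in a range from 4000 nM to 40000 nM.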

Compound 4, half-maximal inhibitory concentration: > 100000 nM
Compound 4: a limit, no number; the forecaster's own chance of this, stated with the estimate: 10%; middle value at least 8.3-fold (0.92 log units) away from the limit.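

In this assay compound 4 gives a limit of the assay and not a number: the limit of > 100000 nM in this assay, at which 2 of the 4 values shown sit.

Until now the steps had only exchanged the group on the chain carbon bound to the sulfur, and the exchange from 2,5-dichlorophenyl to benzyl stayed within the scatter; extending phenethylsulfanyl to (3-phenylpropyl)sulfanyl gives an at least 8.4-fold higher number from compound 3 to compound 4 (0.92 log units; beyond the scatter), which shows that this position responds to the length of the chain alone, with the phenyl ring unchanged. Set against the dichlorinated compound, the same chain gives an at least 5.2-fold higher number from compound 1 to compound 4 (0.71 log units; beyond the scatter), while the step between compound 2 and compound 4 cannot be read, as both values are limits.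

From the compounds shown here alone, the true size of the step remains unknown, and a single lengthening cannot show whether the response continues with a still longer chain or depends on the phenyl ring at its end. Also open, going by these compounds, is whether a 3-phenylpropyl chain with an ether oxygen inside it, or with an amine or a carboxylic acid on the ring, would bring a measurable number back.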